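This account rests on a few compounds, and the source may have more. Where it says the series, first, only, none or still open, it means among the compounds named here.

Compound 1 `Cc1ccc2cc(CN(Cc3ccc(F)cc3)Cc3ccc(C(F)(F)F)cc3)c(=O)[nH]c2c1` in a toxicity assay on MDCK cells (Canis lupus familiaris) for cytotoxicity, read by crystal violet staining, with a stated time of 48 h (on this read-out lower numbers stand for higher toxicity in this test and higher numbers for lower toxicity in this test), gives > 33000 nM, which is a limit of the assay and not a number. Compound 3 `CCc1ccc2[nH]c(=O)c(CN(Cc3ccc(OCOC)cc3)Cc3ccc(C(C)(C)C)cc3)cc2c1` likewise gives > 10000 nM in this assay, again a limit rather than a number. Compound 2 `COCOc1ccc(CN(Cc2ccc(C(C)(C)C)cc2)Cc2cc3cc(C)ccc3[nH]c2=O)cc1` is the only one of the three with a number in this assay, where compound 2 gives 6400 nM. For the measured compounds named here, the one measured step, an at least 1.5-fold higher number from compound 2 to compound 3 (0.19 log units; that floor lies within the scatter), concerns methyl in place of hydrogen on a saturated chain carbon bound to an aromatic carbon, and its floor sits within the scatter of this assay. Compound 4 `Cc1ccc2[nH]c(=O)c(CN(Cc3ccc(N(C)C)cc3)Cc3ccc(C(C)(C)C)cc3)cc2c1` differs from compound 2 by dimethylamino in place of methoxymethoxy on an aromatic carbon. No measured step touches that place; the step from compound 2 to compound 3 concerns a different position, and no other pair among the three shown is informative here. The step from compound 2 to compound 4 in this assay is therefore expected to be no change at the digits printed from compound 2 to compound 4 (within the scatter), nothing beyond the scatter. Compound 4 is estimated at 6400 nM in this assay, between 2500 nM and 16000 nM.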

Compound 4, half-maximal cytotoxic concentration: > 5000 nM
Compound 4 was reported as a limit; the forecaster's own chance of this, stated with the estimate: 30%; the middle value lies beyond the limit too.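

In this assay compound 4 gives > 5000 nM, which is a limit of the assay and not a number. The step from compound 2 to compound 4 therefore cannot be read. The compounds shown leave open whether dimethylamino in place of methoxymethoxy on an aromatic carbon changes the number at all.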